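Trimming a Crown Ether Ester to an Acetate

The compounds below may be only part of what the source reports. "The series", "measured", "known", "first", "only" and "open" are said of these compounds alone.

Three esters of a shared crown ether core have been measured in a functional assay on SW1573 cells (Homo sapiens) for inhibition, read by sulforhodamine B assay, with a stated time of 48 h; on this read-out higher numbers stand for weaker inhibition of growth and lower numbers for stronger inhibition of growth. Compound 1 `O=C(CCCCCc1ccccc1)OCC1COCCOCCOCCOCCOCCO1` gives 78000 nM. Compound 2 `CC(C)=CC1C(C(=O)OCC2COCCOCCOCCOCCOCCO2)C1(C)C` gives 54000 nM. Compound 3 `O=C(OCC1COCCOCCOCCOCCOCCO1)c1cccc(-c2ccc(Br)cc2)c1` gives 4400 nM. Compound 2 thus holds the second highest number of the three: its nearest neighbour is compound 1, with a difference that sits within the scatter, and its furthest is compound 3, whose number is lower by a margin well beyond the scatter.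

The unmeasured compound 4 `CC(=O)OCC1COCCOCCOCCOCCOCCO1` keeps the same core and ester linkage but carries the smallest acyl group of the set: methyl in place of 2,2-dimethyl-3-(2-methylprop-1-en-1-yl)cyclopropyl on a carbonyl carbon. Among the measured compounds shown here, only one measured step bears directly on this change, a 1.4-fold lower number from compound 1 to compound 2 (0.16 log units; within the scatter), and it lies within the scatter, so swapping one large acyl group for another of similar size moved nothing. For the measured compounds named here, compound 3 shows that an aryl acyl group gives a clearly lower number, but no measured step leads to an acyl group as small as methyl. Going by the values given here, with no step to point the other way, compound 4 is expected to give a number at or above that of compound 2, an expected step of a 1.9-fold higher number from compound 2 to compound 4 (0.27 log units; within the scatter) in this assay. The estimate for compound 4 is 100000 nM, with a range from 40000 nM to 250000 nM.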

Compound 4, concentration for 50% growth inhibition: > 100000 nM
Compound 4: a limit, no number (the forecaster's own chance of this, stated with the estimate: 30%); the middle value lies on the limit itself.
By their numbers in this assay, from the lowest: compound 3; then compounds 2 and 1 (each within the scatter of the next). At a limit, above all of these: compound 4.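

Compound 4 in this assay gives > 100000 nM, which is a limit of the assay and not a number: the limit of > 100000 nM in this assay, at which 1 of the 4 values shown sits.

Only floors can be read for the two changes, an at least 1.8-fold higher number from compound 2 to compound 4 (0.26 log units; that floor lies within the scatter) for methyl at the carbonyl carbon and an at least 1.2-fold higher number from compound 1 to compound 4 (0.10 log units; that floor lies within the scatter) for the loss of the 4-phenylbutyl chain, and neither floor shows a change beyond the scatter on its own. What compound 4 adds is that the position now holds an acyl group that yields no number at all on this read-out, whereas compound 3 gives 4400 nM with its bromine-bearing aryl acyl group.

Going by these compounds, how far compound 4 really lies past its limit stays open, and with it whether methyl differs from the larger acyl groups by more than the scatter. Also open, on these data alone, is whether a plain phenyl ring on the carbonyl carbon, or an acyl group carrying an amine or a carboxylic acid, would give a number as low as that of compound 3.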